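A few compounds are considered here, and "the series" means these few. Any claim that something is new, unique, unknown or untested is made for them only; others in the source may bear on it.

In a functional assay on A549 cells (Homo sapiens) for inhibition, read by MTT assay, with a stated time of 72 h (on this read-out lower numbers stand for stronger inhibition and higher numbers for weaker inhibition), compound 1 (`COc1cc2c(Oc3ccc(NC(=O)c4nn(-c5ccccc5C)cc(C)c4=O)cc3)ccnc2cc1OCCCCCCC(=O)NO`) gives 3130 nM and compound 2 (`COc1cc2c(Oc3ccc(NC(=O)c4nn(-c5ccc(F)c(Cl)c5)cc(C)c4=O)cc3)ccnc2cc1OCCCCCCC(=O)NO`) gives 380 nM as the lower of the two numbers. Compound 3 (`COc1cc2c(Oc3ccc(NC(=O)c4nn(-c5ccc(C)cc5C)cc(C)c4=O)cc3)ccnc2cc1OCCCCCCC(=O)NO`) is still unmeasured and differs from compound 2 as follows (2,4-dimethylphenyl in place of 3-chloro-4-fluorophenyl on an aromatic nitrogen): 2,4-dimethylphenyl in place of 3-chloro-4-fluorophenyl on an aromatic nitrogen. Going by the values given here, the one measured step that bears on this is an 8.2-fold lower number from compound 1 to compound 2 (0.92 log units; beyond the scatter) with the reverse kind of exchange at that nitrogen, modest but beyond the scatter. The 2,4-dimethylphenyl group resembles the 2-methylphenyl of compound 1 (3130 nM) more than the group it replaces, so much of that step is expected to reverse. A higher number beyond the scatter is therefore expected in this assay although a single pair is thin evidence. The expected size is a 3.9-fold higher number from compound 2 to compound 3 (0.60 log units; beyond the scatter) on this estimate. For compound 3 the estimated value is 1500 nM with an expected range (500 nM to 4500 nM).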

Compound 3, half-maximal inhibitory concentration: 1840 nM
For compound 3 the middle estimate is 1.2-fold (0.09 log units) below the measured one; low and high end bracket the measured number.
By their numbers in this assay, from the lowest: compound 2; then compounds 3 and 1 (each within the scatter of the next).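

In this assay, 2,4-dimethylphenyl in place of 3-chloro-4-fluorophenyl on the aromatic nitrogen gives a 4.8-fold higher number from compound 2 to compound 3 (0.69 log units; beyond the scatter), so this second exchange at the position also separates a halogen-bearing aryl group from a methyl-bearing one. The extra methyl that distinguishes compound 3 from compound 1 gives a 1.7-fold lower number from compound 1 to compound 3 (0.23 log units; within the scatter), so that single addition does not separate the two compounds, and both stand apart from compound 2. Nothing on hand gives a reason for these differences.

On these data alone, the exchanges change the kind of substituent and its place on the ring together, so neither can be read alone, and the separate shares of the chlorine and the fluorine stay unknown. As far as these compounds go, whether an unsubstituted phenyl, a methoxyphenyl or a pyridine ring on this nitrogen would fall with compound 2 or with compounds 1 and 3 also stays open.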